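The compounds below may be only part of what the source reports. "The series", "measured", "known", "first", "only" and "open" are said of these compounds alone.

Three compounds on the shared core of compound 1 `O=c1ccc(-c2ccccc2)nn1CCCCNC(=S)Nc1ccc(Cl)cc1` have been run in a functional assay on the whole organism with Rattus norvegicus as the target, at a dose of 100 mg/kg (on this read-out higher numbers stand for more inhibition at the one dose given (going by the name of the read-out) and lower numbers for less inhibition), where compound 1 gives 43.2%. Compound 2 `O=c1ccc(-c2ccccc2)nn1CCCCNC(=S)NC1CCCCC1` gives 18.1% and compound 3 `O=c1ccc(-c2ccccc2)nn1CCCCNC(=S)NCc1ccccc1` gives 5.4%. Compound 2 thus stands second of the three: a number 25.1 percentage points lower from compound 1 to compound 2 (beyond the scatter), whereas a number 12.7 percentage points lower from compound 2 to compound 3 (beyond the scatter); the widest gap is a number 37.8 percentage points lower from compound 1 to compound 3 (beyond the scatter). Compound 4 `N#CNC(=N)NCCCCn1nc(-c2ccccc2)ccc1=O` differs from compound 2 by a group of 5 heavy atoms (2 carbon, 3 nitrogen; no ring) in place of a group of 9 heavy atoms (7 carbon, 1 nitrogen, 1 sulfur; one six-membered non-aromatic ring of carbon only), on an amine nitrogen. Within the data shown here, none of the measured steps bears directly on this change; all three exchange one ring-bearing group for another on the same nitrogen, and the two modest ones suggest that swaps at this position need not move the read-out far. For compound 4 a step of a number 3.1 percentage points lower from compound 2 to compound 4 (within the scatter) is expected in this assay, within the scatter. Compound 4 is therefore estimated at 15%, in the range 0% to 35%.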

Compound 4, a percentage reported as inhibition, in the whole organism at one dose (the size of the read-out at that dose, not a potency): 61.2%
The estimate for compound 4 lay 46.2 percentage points below the measured number; measured number outside the range, above it.
By their numbers in this assay, from the lowest: compound 3; then compound 2; then compound 1; then compound 4.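

In this assay, among these compounds, the ring-free group of 5 heavy atoms (2 carbon, 3 nitrogen) on the amine nitrogen gives a number 43.1 percentage points higher from compound 2 to compound 4 (beyond the scatter), the only measured change here that raises the number from compound 2 . The earlier steps exchanged only ring-bearing groups, so a ring at this position is now shown not to be required for inhibition at this dose. Nothing available here accounts for the size of this step.

Which atoms of the entering group carry the step stays open, since the nitrile and the rest of the group change together. On these data alone, whether a smaller group, such as acetyl or methyl, on this amine nitrogen keeps the number also remains open.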